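The source may hold more compounds than are shown below. What is called first, only, known or untested is meant among the compounds shown, and "the series" means these compounds.

Of the compounds shown here, three have so far been measured in a physicochemical assay for lipophilicity, at pH 7.4; a lower number here means a more polar compound, a higher number a more lipophilic compound. Compound 1 `CNC(=O)c1cc(C(=O)NC2CCC2)cn(Cc2cccc(NC)c2)c1=O` gives 3.6, compound 2 `CNC(=O)c1ccc(=O)n(Cc2cc(Br)ccc2F)c1` gives 2.6, and compound 3 `CNC(=O)c1cc(C(=O)NC2CC2)cn(CC2CCOCC2)c1=O` gives 1.5, the lowest of the three, with compound 2 standing beyond the scatter above it and compound 1 further still. Compound 4 `CNC(=O)c1cc(C(=O)NC2CC2)cn(Cc2cccc3[nH]ccc23)c1=O` has not yet been measured; it differs from compound 3 in one place: 1H-indol-4-yl in place of oxan-4-yl on a saturated chain carbon bound to an aromatic nitrogen. Among the measured compounds shown here, no step between measured compounds is available, so the expectation rests on the whole set. Because compound 1 gives 3.6 and compound 2 gives 2.6, both carrying aromatic groups on the saturated chain carbon bound to an aromatic nitrogen, a sizeable upward step a number 1.50 log units higher from compound 3 to compound 4 (beyond the scatter) is expected. Compound 4 is therefore estimated at 3, within 2.4 to 3.6.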

Compound 4, distribution coefficient: 2.9
Beside the measured number, compound 4's estimate is 0.10 log units above it; low and high end bracket the measured number.
By their numbers in this assay, from the lowest: compound 3; then compounds 2 and 4 (each within the scatter of the next); then compound 1.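

In this assay, the change to 1H-indol-4-yl in place of oxan-4-yl on a saturated chain carbon bound to an aromatic nitrogen gives a number 1.40 log units higher from compound 3 to compound 4 (beyond the scatter) with the rest of the molecule unchanged. Among the compounds shown here, this shows that a change at this position alone can produce a large step, which the earlier compounds, with no single-place pair among them, could not show. Nothing at hand accounts for the step.

The change alters ring type, ring count and hydrogen-bond donor count at once, so the compounds shown do not separate these features. Going by these compounds, how a simple phenyl or a piperidine at this place would compare with compound 3 and compound 4 remains open.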